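Ester chain length and branching at the ring nitrogen

The source may report more compounds than this note shows. Statements on the series, on what has been measured and on what is new or still open speak of the compounds shown alone.

The series rests on the shared core of compound 1 `COC(=O)CN1C(=O)c2ccccc2NC1c1ccccc1`, which in an assay on mitochondria for inhibition of Amine oxidase [flavin-containing] B (Bos taurus), read by fluorescence, with a stated time of 60 min (on this read-out lower numbers stand for stronger inhibition and higher numbers for weaker inhibition), gives 720000 nM. Compound 2 `COC(=O)CN1C(=O)c2ccccc2NC1c1ccco1` gives 380000 nM, the step being a 1.9-fold lower number from compound 1 to compound 2 (0.28 log units; within the scatter). Compound 3 `COC(=O)C(C)N1C(=O)c2ccccc2NC1c1ccco1` gives 61000 nM, the step being a 6.2-fold lower number from compound 2 to compound 3 (0.79 log units; beyond the scatter). On the numbers shown compound 3 stands lowest of the three, with compound 2 the nearest and compound 1 the furthest.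

Compound 4 `COC(=O)CCCN1C(=O)c2ccccc2NC1c1ccco1` differs from compound 3 by 3-(methoxycarbonyl)propyl in place of 1-(methoxycarbonyl)ethyl on an amide-type nitrogen in a ring. Among the measured compounds shown here, of the measured steps only a 6.2-fold lower number from compound 2 to compound 3 (0.79 log units; beyond the scatter) bears on this change, and only in part: the methyl that entered there leaves again in compound 4, while the longer chain has no counterpart among the measured compounds. Because a 6.2-fold lower number from compound 2 to compound 3 (0.79 log units; beyond the scatter) rested on that methyl, its departure is expected to give back much of the gain, and the longer chain is an open question. For compound 4 a step of a 3.3-fold higher number from compound 3 to compound 4 (0.52 log units; beyond the scatter) is therefore expected, toward weaker inhibition. Compound 4 is estimated at 200000 nM in this assay, with a range of 50000 nM to 700000 nM.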

Compound 4, half-maximal inhibitory concentration: 780000 nM
Beside the measured number, compound 4's estimate is 3.9-fold (0.59 log units) below it; measured number outside the range, above it.
By their numbers in this assay, from the lowest: compound 3; then compounds 2, 1 and 4 (each within the scatter of the next, the first and the last beyond it).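

In this assay, among the compounds shown here, the group on the amide-type nitrogen in a ring can move the number in the weaker direction as well as the stronger: 3-(methoxycarbonyl)propyl in place of 1-(methoxycarbonyl)ethyl gives a 13-fold higher number from compound 3 to compound 4 (1.11 log units; beyond the scatter) and is the largest step so far. Extending the unbranched chain of compound 2 gives a 2.1-fold higher number from compound 2 to compound 4 (0.31 log units; beyond the scatter), a modest step that also runs toward weaker inhibition, so among these compounds a longer unbranched chain does not reproduce the gain from the methyl on the chain carbon. No measurement at hand accounts for either step.

Still open, on these data alone, is whether the gain belongs to the methyl on the chain carbon alone or would survive an ethyl or a larger branch there, and whether a methyl on the longer chain of compound 4 would recover any of the lost inhibition. Also open, as far as these compounds go, is how a carboxylic acid or a primary amide in place of the methyl ester would behave at this position, and whether these chain changes carry over to the phenyl-bearing compound 1.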